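A Thioether Swap on an Inactive Anilide Pair

The source may report more compounds than this note shows. Statements on the series, on what has been measured and on what is new or still open speak of the compounds shown alone.

Measured so far:
compound 1, `O=C(Nc1ccc(OC(F)F)cc1)c1cccc(/C=C2\CC(=O)N(c3ccccc3)C2=O)c1`, gives > 100000 nM
compound 2, `COc1ccc(NC(=O)c2cccc(/C=C3\CC(=O)N(c4ccccc4)C3=O)c2)cc1`, gives > 100000 nM

Both measured compounds share one core and differ only in the group on the ether oxygen. In an ADME assay on SW480 cells (Homo sapiens) for cytotoxicity, read by MTT assay, with a stated time of 72 h (a lower number here means a stronger inhibitor, a higher number a weaker inhibitor), compound 1 gives > 100000 nM, which is a limit of the assay and not a number. In this assay compound 2 gives > 100000 nM, again a limit rather than a number. Among the measured compounds shown here, the only measured step, a step that the two limits leave unreadable from compound 1 to compound 2, therefore has no readable size. Compound 2 thus stands at the limit, and both shown values sit there (the limit of > 100000 nM in this assay, at which 2 of the 2 values shown sit).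

Compound 3, `CSc1cccc(NC(=O)c2cccc(/C=C3\CC(=O)N(c4ccccc4)C3=O)c2)c1`, differs from compound 2 by 3-(methylsulfanyl)phenyl in place of 4-methoxyphenyl on an amide-type nitrogen. For the measured compounds named here, no measured step bears directly on this change; the one step known, a step that the two limits leave unreadable from compound 1 to compound 2, is itself unreadable. With both shown values at the limit, there is no basis for expecting compound 3 to reach a measurable number. Compound 3 is therefore expected to give about 100000 nM, with a range from 30000 nM to 300000 nM, most likely again as a limit. That corresponds to an expected step of a number no higher from compound 2 to compound 3 (the limit leaves the size open), none beyond the scatter.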

Compound 3, half-maximal inhibitory concentration: 74300 nM
For compound 3 the middle estimate is 1.3-fold (0.13 log units) above the measured one; the measured number falls inside the stated range.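

In this assay, among the compounds shown here, compound 3 gives 74300 nM, the first reading in this set that is a number and not a limit, so a change on the amide-type nitrogen can bring this shared core into the range the assay can read. Set against the earlier pair, the result is an at least 1.3-fold lower number from compound 2 to compound 3 (0.12 log units; that floor lies within the scatter) and an at least 1.3-fold lower number from compound 1 to compound 3 (0.12 log units; that floor lies within the scatter); these are floors, so the true gaps may be larger, but what is known so far does not go beyond the scatter. The other two values remain limits, not numbers: the limit of > 100000 nM in this assay, at which 2 of the 3 values shown sit.

The change from 4-methoxyphenyl to 3-(methylsulfanyl)phenyl alters both the atom, oxygen to sulfur, and the numbered place of the group in a single step, so the compounds shown cannot tell which of the two matters. A 3-methoxyphenyl or a 4-(methylsulfanyl)phenyl group on the same nitrogen would separate the two, and a longer chain on the sulfur, such as ethylsulfanyl, would show whether the reading holds.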